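Benzylamine variation on a bis(trifluoromethyl)benzenesulfonamide scaffold

The source may report more compounds than this note shows. Statements on the series, on what has been measured and on what is new or still open speak of the compounds shown alone.

Measured in a functional assay on HPAC cells (Homo sapiens) for inhibition, read by MTT assay, with a stated time of 72 h (a higher number here means a weaker inhibitor of growth, a lower number a stronger inhibitor of growth), so far:
compound 1 `O=S(=O)(NCCCNCc1ccc(Cl)c(C(F)(F)F)c1)c1cc(C(F)(F)F)cc(C(F)(F)F)c1` gives 3000 nM
compound 2 `O=S(=O)(NCCCNCc1ccc(C(F)(F)F)cc1)c1cc(C(F)(F)F)cc(C(F)(F)F)c1` gives 2700 nM
compound 3 `O=S(=O)(NCCCNCc1ccc(Br)cc1)c1cc(C(F)(F)F)cc(C(F)(F)F)c1` gives 2900 nM

The three compounds share one core and differ only in the aryl group on a saturated chain carbon bound to an amine nitrogen. Their numbers in this assay lie close together: the step of a 1.1-fold lower number from compound 1 to compound 2 (0.05 log units; within the scatter) and the step of a 1.0-fold lower number from compound 1 to compound 3 (0.01 log units; within the scatter) are both within the scatter, as is the step of a 1.1-fold higher number from compound 2 to compound 3 (0.03 log units; within the scatter). Compound 3 therefore stands among the others with no separation that the assay can resolve.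

Compound 4 `O=S(=O)(NCCCNCc1cccc(Cl)c1)c1cc(C(F)(F)F)cc(C(F)(F)F)c1` is the next member. Its change from compound 3 is 3-chlorophenyl in place of 4-bromophenyl on a saturated chain carbon bound to an amine nitrogen. Every replacement of the aryl group seen so far, whether of the whole ring or of a single halogen for trifluoromethyl, has left the number in this assay essentially unmoved, and a chloro group set on the ring in this way lies within the same range of substituents. Compound 4 is accordingly expected to show a step of a 1.0-fold higher number from compound 3 to compound 4 (0.01 log units; within the scatter), with no movement beyond the scatter. The estimate for compound 4 in this assay is 3000 nM, with a range from 1500 nM to 6000 nM.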

Compound 4, concentration for 50% growth inhibition: 2700 nM
Compound 4: middle estimate off by 1.1-fold (0.05 log units), on the high side, within the range that was stated.
By their numbers in this assay, from the lowest: compounds 2, 4, 3 and 1 (each within the scatter of the next).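

For the compounds shown here, until this point every aryl group on a saturated chain carbon bound to an amine nitrogen was a 4-substituted one (4-bromophenyl, 4-(trifluoromethyl)phenyl, 4-chloro-3-(trifluoromethyl)phenyl), and 3-chlorophenyl is the first with no group named at 4. In this assay the three new comparisons read a 1.1-fold lower number from compound 3 to compound 4 (0.03 log units; within the scatter) and no change at the digits printed from compound 2 to compound 4 (within the scatter) and a 1.1-fold lower number from compound 1 to compound 4 (0.05 log units; within the scatter), so among these four compounds the number does not depend on a substituent named at 4, on bromo, chloro or trifluoromethyl as the ring group, or on whether the ring bears one group or two. Nothing available explains why these aryl groups cannot be told apart in this cell assay.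

Going by these compounds, all four compounds keep the same chain and the same sulfonamide portion and carry only halogen or trifluoromethyl groups on the benzyl ring, so it remains open whether a hydroxyl, a methoxy group or a carboxylic acid on that ring would separate from them. On these data alone, it is equally open whether a longer chain between the two nitrogens, or a methyl group on the amine nitrogen, would give a number outside this tight cluster.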